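The source may report more compounds than this note shows. Statements on the series, on what has been measured and on what is new or still open speak of the compounds shown alone.

Measured so far:
compound 1, `COc1cc2nc(NCc3ccccc3)nc(NC3CCCCCC3)c2cc1OC`: < 0%
compound 2, `COc1cc2nc(N3CCC(N4CCCC4)CC3)nc(NCc3ccccc3)c2cc1OC`: < 0%

Both were tested in an in vitro assay on B300-19 cells for displacement of a labelled ligand from C-C chemokine receptor type 4 (Homo sapiens), tested at 1 uM; on this read-out lower numbers stand for less inhibition and higher numbers for more inhibition at the one concentration tested (going by the name of the read-out). For compound 1 the reading of < 0% is a limit of the assay rather than a number. For compound 2 the reading of < 0% is likewise a limit. Compound 1 therefore stands at the floor of what has been shown so far, and (the limit of < 0% in this assay, at which 2 of the 2 values shown sit). Among the compounds with values here, no pair of measured compounds differing in a single place is available, so no step size can be read off from data; any step can only be expected.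

Compound 3, `COc1cc2nc(N3CCC(C(N)=O)CC3)nc(NC3CCCCCC3)c2cc1OC`, has not yet been measured. It differs from compound 1 in one place: 4-carbamoylpiperidin-1-yl in place of benzylamino on an aromatic carbon. With compound 1 sitting at a limit, the step of a number at least 5 percentage points higher from compound 1 to compound 3 (that floor lies within the scatter) is expected to be small, either none beyond the scatter or a modest rise, since the shared core with a cycloheptylamino group has given only a limit so far. Compound 3 is expected to give about 5% in this assay, most likely somewhere from 0% to 25%.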

Compound 3, a percentage reported as inhibition, at one concentration (the size of the read-out at that concentration, not a potency): < 0%
Compound 3 was reported as a limit; the forecaster's own chance of this, stated with the estimate: 55%; middle value at least 5 percentage points away from the limit.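

Compound 3, like compound 1, is reported only as a limit, so the change to 4-carbamoylpiperidin-1-yl in place of benzylamino gives no step of readable size in this assay, and the same holds across all the compounds shown: the limit of < 0% in this assay, at which 3 of the 3 values shown sit. The compounds shown leave open whether any change to the shared core gives measurable inhibition at the one concentration tested.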